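The source may hold more compounds than are shown below. What is called first, only, known or untested is meant among the compounds shown, and "the series" means these compounds.

Measured compounds:

Compound 1 `Cc1ccc(C(=O)O)cc1OCCCCOc1ccc(C(=O)CC2CCCC2)c(O)c1C`: in an assay on HEK293 cells for positive allosteric modulation of metabotropic glutamate receptor 3 (Rattus norvegicus), read by thallium flux, with a stated time of 2.5 min (a lower number here means that less compound is needed, a higher number that more compound is needed for the effect), compound 1 gives > 10000 nM, which is a limit of the assay and not a number.

Compound 2 `CCC(=O)c1ccc(OCCCCOc2ccc(C(=O)O)cc2C)c(C)c1O`: in this assay compound 2 gives "not determined" (no result reported).

Compound 3 `CC(=O)c1ccc(OCCCCOc2ccc(C(=O)O)cc2C)c(C)c1O`: in this assay compound 3 gives "not determined" (no result reported).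

Compound 3 therefore stands without a number of its own. Among the three compounds only compound 1 has an entry that can be read, and that entry is a limit, as the limit of > 10000 nM in this assay, at which 1 of the 3 values shown sits, records, while compound 2 likewise carries no result. Among the measured compounds shown here, no comparison between measured compounds is possible here, so no step size has been observed.

The compound that remains to be measured is compound 4 `Cc1cc(C(=O)O)ccc1OCCCCOc1ccc(C(=O)CC2CCCC2)c(O)c1C`. It differs from compound 3 in one place: cyclopentyl in place of hydrogen on a saturated chain carbon bound to a carbonyl carbon. For the measured compounds named here, compound 4 also shares its ketone side chain and its acid-bearing ring with compound 1, the only compound for which an entry exists in this assay.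

Going by the values given here, with no measured step to lean on, no direction or size of change can be expected beyond the ordinary scatter. Given that the closest comparison, compound 1, shows > 10000 nM as a limit in this assay, compound 4 is expected to sit near that limit as well, estimated at 10000 nM with a range from 3000 nM to 30000 nM.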

Compound 4, half-maximal effective concentration: > 10000 nM
Compound 4: a limit, no number; the forecaster's own chance of this, stated with the estimate: 70%; the middle value sits exactly at the limit.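

In this assay compound 4 gives > 10000 nM, which is a limit of the assay and not a number. Compound 1 also carries a limit, so no step between compound 1 and compound 4 can be read: the limit of > 10000 nM in this assay, at which 2 of the 4 values shown sit.

The compounds shown give no single number in this assay, which leaves open what cyclopentyl in place of hydrogen does to the effect.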